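The compounds below may be only part of what the source reports. "The series", "measured", "known", "first", "only" and "open" are said of these compounds alone.

Among the measured compounds shown here, in a physicochemical assay for solubility, read by LC-MS, in phosphate buffer, with a stated time of 24 h, at pH 6.8 (on this read-out lower numbers stand for lower solubility and higher numbers for higher solubility), compound 2 `CCC(=O)N[C@@H](C)c1ccc(NC(=O)N2CC(c3cccnc3)C2)cc1` gives 700000 nM, the highest of the three numbers so far. Compound 1 `C[C@H](NC(=O)C1CCOCC1)c1ccc(NC(=O)N2CC(c3cccnc3)C2)cc1` gives 380000 nM. That measured step, a 1.8-fold higher number from compound 1 to compound 2 (0.27 log units; within the scatter), swaps ethyl for oxan-4-yl, so it says little about the change at hand. Compound 4 `CCC(=O)N[C@@H](C)c1ccc(NC(=O)N2CC(c3ccc(N)nc3)C2)cc1` has amino in place of hydrogen on an aromatic carbon, turning pyridin-3-yl into 6-aminopyridin-3-yl. For the measured compounds named here, no measured step isolates this change. Compound 3 `C[C@H](NC(=O)c1cccc(F)c1)c1ccc(NC(=O)N2CC(c3ccc(N)nc3)C2)cc1` carries the same 6-aminopyridin-3-yl group and gives a much lower 32000 nM, yet it also differs from compound 2 elsewhere. A downward move in this assay is therefore expected, but a smaller one than that gap. The expected step is a 2.8-fold lower number from compound 2 to compound 4 (0.45 log units; beyond the scatter). For compound 4 the estimated value is 250000 nM, with an expected range of 70000 nM to 700000 nM.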

Compound 4, solubility: 760000 nM
The estimate for compound 4 lay 3.0-fold (0.48 log units) below the measured number, and the stated range ends below it.
By their numbers in this assay, from the lowest: compound 3; then compounds 1, 2 and 4 (each within the scatter of the next).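

In this assay, among the compounds shown here, the change from pyridin-3-yl to 6-aminopyridin-3-yl, read on its own for the first time, gives a 1.1-fold higher number from compound 2 to compound 4 (0.04 log units; within the scatter) and so shows no real shift with ethyl on the carbonyl. With the 6-aminopyridin-3-yl group held fixed, ethyl in place of 3-fluorophenyl gives a 24-fold higher number from compound 3 to compound 4 (1.38 log units; beyond the scatter) and so places the wide gap to compound 3 at that carbonyl substituent, not at the amino group. No measured evidence here explains either step.

From the compounds shown here alone, whether amino behaves the same way with 3-fluorophenyl on the carbonyl remains open. So does the outcome with a methoxy or dimethylamino group at the same ring position.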